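Acyl and aryl variation in a weakly active kinase series

The source may hold more compounds than are shown below. What is called first, only, known or untested is meant among the compounds shown, and "the series" means these compounds.

Measured compounds:
compound 1 `CC(=O)n1nc(C)c(-c2ccc(Cl)c(Cl)c2)c1N`: > 100000 nM
compound 2 `Cc1nn(C(=O)C2CC2)c(N)c1-c1ccc(Cl)c(Cl)c1`: > 100000 nM
compound 3 `CC(=O)n1nc(C)c(-c2ccc(Cl)cc2)c1N`: > 100000 nM

In an assay on Sf9 cells for inhibition of inhibitor of nuclear factor kappa-B kinase subunit epsilon (Homo sapiens), read by ADP-Glo, with a stated time of 60 min (a higher number here means a weaker inhibitor, a lower number a stronger inhibitor), compound 1 gives > 100000 nM, which is a limit of the assay and not a number. In this assay compound 2 gives > 100000 nM, again a limit. In this assay compound 3 gives > 100000 nM, also a limit.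

The step that the two limits leave unreadable from compound 1 to compound 2 is made by cyclopropyl in place of methyl on a carbonyl carbon. The step that the two limits leave unreadable from compound 1 to compound 3 is made by hydrogen in place of chloro on an aromatic carbon, which is how the two cores differ. Within the data shown here, every value measured so far sits at the limit of > 100000 nM in this assay, at which 3 of the 3 values shown sit, so neither step can be sized.

Compound 4 `Cc1nn(C(=O)C2CC2)c(N)c1-c1ccc(Cl)cc1` remains to be measured. It differs from compound 3 by cyclopropyl in place of methyl on a carbonyl carbon. The place is described in the same words as for the change from compound 1 to compound 2, so this is the same change made on the other core.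

With no readable step to build on, compound 4 is expected to behave like compound 3 and reach only the limit in this assay. The step of a number no higher from compound 3 to compound 4 (the limit leaves the size open) is thus estimated as flat. The estimate for compound 4 is 100000 nM, within 30000 nM to 300000 nM.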

Compound 4, half-maximal inhibitory concentration: > 100000 nM
Compound 4: a limit, no number; the forecaster's own chance of this, stated with the estimate: 90%; the middle value sits exactly at the limit.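

In this assay compound 4 gives > 100000 nM, which is a limit and not a number, so the steps to compound 4 from compound 3 and from compound 2 cannot be read: the limit of > 100000 nM in this assay, at which 4 of the 4 values shown sit.

The compounds shown leave open whether either change, methyl to cyclopropyl or chloro to hydrogen, affects inhibition at all, since none gives a number.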